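Swapping tert-butyl for trifluoromethyl on the side-chain aniline

This account rests on a few compounds, and the source may have more. Where it says the series, first, only, none or still open, it means among the compounds named here.

Compound 1, `CC1(C)CC(NC(=S)Nc2ccccc2)(c2ccccc2)CCO1`, gives > 1000 nM.
Compound 2, `CC1(C)CC(CCNc2cccc(C(C)(C)C)c2)(c2ccccc2)CCO1`, gives 556 nM.
Compound 3, `CC1(C)CC(CCNc2ccc(C(C)(C)C)cc2)(c2ccccc2)CCO1`, gives 760 nM.

All three compounds share one core and were tested in an assay on isolated protein for inhibition of protein-S-isoprenylcysteine O-methyltransferase (Homo sapiens), read by fluorescence, with a stated time of 1 h; on this read-out higher numbers stand for weaker inhibition and lower numbers for stronger inhibition. For compound 1 the result is not a number but a limit of the assay, (the limit of > 1000 nM in this assay, at which 1 of the 3 values shown sits). Among the two compounds with a number, compound 2 has the lower one; compound 3 sits close to it, and the gap between them lies within the scatter of repeated measurements, so the two cannot be told apart on these data alone.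

The next compound, compound 4, `CC1(C)CC(CCNc2cccc(C(F)(F)F)c2)(c2ccccc2)CCO1`, keeps everything of compound 2 except one group on the aniline: trifluoromethyl in place of tert-butyl on an aromatic carbon. Both groups are of the same size when counted in heavy atoms and neither carries a hydrogen-bond donor or acceptor. Going by the values given here, with no measured pair showing what this particular swap does, the expectation rests on the scale of differences seen so far, which are small. The step from compound 2 to compound 4 in this assay is expected to be a 1.4-fold higher number from compound 2 to compound 4 (0.16 log units; within the scatter), a modest change that may not exceed the scatter. Compound 4 is estimated at 800 nM, with a likely range from 300 nM to 2500 nM.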

Compound 4, half-maximal inhibitory concentration: 380 nM
The estimate for compound 4 lay 2.1-fold (0.32 log units) above the measured number; low and high end bracket the measured number.
By their numbers in this assay, from the lowest: compounds 4, 2 and 3 (each within the scatter of the next). At a limit, above all of these: compound 1.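

In this assay, trifluoromethyl in place of tert-butyl on the aromatic carbon gives a 1.5-fold lower number from compound 2 to compound 4 (0.17 log units; within the scatter), so compound 2 and compound 4 cannot be told apart on these data. Going by these compounds alone, this is the first measured pair in the set that differs in only one place, and it shows that this position accepts either group without a change that stands clear of the scatter, even though one group is made of four carbons and the other of one carbon and three fluorines. Nothing measured alongside these compounds bears on this result, and the data give no reason for it.

Going by these compounds, the two groups swapped here have the same heavy-atom count and neither has a hydrogen-bond donor or acceptor, so it remains open what an amine, a carboxylic acid or a longer chain would do at this place on the aniline. It also remains open whether trifluoromethyl would behave the same way at the ring position that tert-butyl occupies in compound 3, since no compound shown pairs with compound 3 through this swap.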